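Compound 4: An Expected Step Down from Compound 3

The compounds below may be only part of what the source reports. "The series", "measured", "known", "first", "only" and "open" are said of these compounds alone.

Of the compounds shown here, three built on one shared core have been measured in a functional assay on MCF7 cells (Homo sapiens) for inhibition, read by MTT assay, with a stated time of 48 h; on this read-out lower numbers stand for stronger inhibition and higher numbers for weaker inhibition. There, compound 1 `CCOC(=O)C1=C(N/C=N/c2cccnc2Cl)Nc2[nH]nc(C)c2C1c1ccc(N(C)C)cc1` gives 4180 nM, compound 2 `CCOC(=O)C1=C(NN=C(C(C)=O)C(C)=O)Nc2[nH]nc(C)c2C1c1ccc(N(C)C)cc1` gives 9740 nM, and compound 3 `CCOC(=O)C1=C(N/C=N/c2nnc(S(N)(=O)=O)s2)Nc2[nH]nc(C)c2C1c1ccc(N(C)C)cc1` gives 34500 nM. Compound 3 therefore has the highest number of the three and is the weakest inhibitor in this small set, with its steps to both others beyond the scatter.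

The next compound, compound 4 `CCOC(=O)C1=C(N/C=N/c2ncc(-c3ccccc3)s2)Nc2[nH]nc(C)c2C1c1ccc(N(C)C)cc1`, carries 5-phenyl-1,3-thiazol-2-yl in place of 5-sulfamoyl-1,3,4-thiadiazol-2-yl on a double-bonded nitrogen. Among the measured compounds shown here, no measured compound carries the entering group, so the evidence is indirect. For the measured compounds named here, the closest precedent changes the same place, an 8.3-fold higher number from compound 1 to compound 3 (0.92 log units; beyond the scatter), and it swaps the leaving group for 2-chloropyridin-3-yl. A change on an amine nitrogen gives a 3.5-fold higher number from compound 2 to compound 3 (0.55 log units; beyond the scatter), while a 2.3-fold higher number from compound 1 to compound 2 (0.37 log units; beyond the scatter) separates the two compounds lacking the sulfamoyl group. Among just these three compounds, the one with that group has the highest number, and none goes against this. Going by the values given here, a modest move to a lower number in this assay is thus expected, no larger than the step seen with compound 1 at 4180 nM. The expected step is a 3.8-fold lower number from compound 3 to compound 4 (0.58 log units; beyond the scatter). For compound 4 the estimated value is 9000 nM, with an expected range from 3000 nM to 27000 nM.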

Compound 4, half-maximal inhibitory concentration: 10100 nM
The estimate for compound 4 lay 1.1-fold (0.05 log units) below the measured number; the measured number falls inside the stated range.
By their numbers in this assay, from the lowest: compound 1; then compounds 2 and 4 (each within the scatter of the next); then compound 3.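

Among the compounds shown here, at the double-bonded nitrogen, the earlier compounds offered only one exchange of groups, and in this assay the new exchange of 5-sulfamoyl-1,3,4-thiadiazol-2-yl for 5-phenyl-1,3-thiazol-2-yl gives a 3.4-fold lower number from compound 3 to compound 4 (0.53 log units; beyond the scatter), so a second group without the sulfamoyl also gives a lower number than the sulfamoyl-bearing one. The 5-phenyl-1,3-thiazol-2-yl group does not match 2-chloropyridin-3-yl, however, with a 2.4-fold higher number from compound 1 to compound 4 (0.38 log units; beyond the scatter), which shows that the three groups at this position give three numbers separated by more than the scatter, not merely a split between sulfamoyl and no sulfamoyl. Nothing measured here accounts for these differences.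

The step from the 5-sulfamoyl-1,3,4-thiadiazol-2-yl group changes the five-membered ring, removes the sulfamoyl and adds a phenyl all at once, so the compounds shown cannot assign it to any one of these parts. A compound with a methyl or a carboxylic acid in place of the phenyl of 5-phenyl-1,3-thiazol-2-yl would show whether that phenyl matters to the number at all, a question these compounds leave open.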